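Compound 1 and its E-drawn counterpart, compound 4

This account rests on a few compounds, and the source may have more. Where it says the series, first, only, none or still open, it means among the compounds named here.

Values in a functional assay on T98G cells (Homo sapiens) for cytotoxicity, read by MTT assay, with a stated time of 48 h (a higher number here means a weaker inhibitor, a lower number a stronger inhibitor), are as follows:
- compound 1 (`CC(=NNC(=S)Nc1cccc([N+](=O)[O-])c1)c1ccccn1`) gives 140 nM
- compound 2 (`CC(=NNC(=S)Nc1cccc(I)c1)c1ccccn1`) gives 61 nM
- compound 3 (`CC(=NNC(=S)Nc1ccccc1)c1ccccn1`) gives 6.8 nM

Compound 1 carries the highest number of the three and is the weakest inhibitor here. Iodo in place of nitro gives a modest step (a 2.3-fold lower number from compound 1 to compound 2 (0.36 log units; beyond the scatter)) and hydrogen in place of nitro a large one (a 21-fold lower number from compound 1 to compound 3 (1.31 log units; beyond the scatter)). Hydrogen in place of iodo gives a further modest step (a 9.0-fold lower number from compound 2 to compound 3 (0.95 log units; beyond the scatter)) in the same series.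

Compound 4 (`C/C(=N\NC(=S)Nc1cccc([N+](=O)[O-])c1)c1ccccn1`) differs from compound 1 in one way only (the two compounds have the same atoms and bonds; at least one stereo element is drawn with a configuration in one of them and without one in the other: 1 of 1 stereo elements differ; a double bond is drawn without a configuration in compound 1 and E in compound 4), and the two compounds have the same atoms and bonds. All three measured steps swap a group on an aromatic carbon, and none of them touches a drawn configuration, so they do not bear directly on this change. The expectation therefore rests on compound 1 (140 nM) alone. No step beyond the scatter is expected in this assay for this change (no change at the digits printed from compound 1 to compound 4 (within the scatter)). The estimate for compound 4 is 140 nM (expected range 65 nM to 300 nM).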

Compound 4, half-maximal inhibitory concentration: 140 nM
Estimate against measurement, compound 4: no gap at the digits printed; the range from low to high includes it.
By their numbers in this assay, from the lowest: compound 3; then compound 2; then compounds 1 and 4 (each within the scatter of the next).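

The earlier compounds shown here in this assay showed only what swapping the group on an aromatic carbon does, whereas this pair isolates how the double bond is drawn and gives no change at the digits printed from compound 1 to compound 4 (within the scatter). With nitro kept in place, an E-drawn double bond and one drawn without a configuration therefore cannot be told apart in this assay, so the low reading of compound 1 among the nitro, iodo and hydrogen compounds also holds for the defined form. The two compounds are separated by one thing only: the fact that one of compounds 1 and 4 is drawn with a defined configuration and the other without, at the place where they differ

As far as these compounds go, whether a double bond drawn Z would read the same stays open. Also open, from the compounds shown here alone, is how an amine or a carboxylic acid in place of nitro on that aromatic carbon would compare with the iodo and hydrogen compounds.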